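This account rests on a few compounds, and the source may have more. Where it says the series, first, only, none or still open, it means among the compounds named here.

Measured so far in a functional assay on V79 cells (Cricetulus griseus) for cytotoxicity, read by colony formation; a lower number here means a stronger inhibitor, a higher number a weaker inhibitor:
Compound 1 `CCNCC1CCN(c2cc3c(c(C)c2F)c(=O)c(C(=O)O)cn3C2CC2)C1`: 42 ug/mL
Compound 2 `CCNCC1CCN(c2c(F)c(F)c3c(=O)c(C(=O)O)cn(C4CC4)c3c2F)C1`: 46 ug/mL
Compound 3 `CCNCC1CCN(c2c(F)c(NC(C)=O)c3c(=O)c(C(=O)O)cn(C4CC4)c3c2F)C1`: > 500 ug/mL

Compound 3 gives > 500 ug/mL, and this is a limit of the assay, not a number. Its place in this assay is therefore known only as a limit.

Compound 4 `CCNCC1CCN(c2c(F)c(C)c3c(=O)c(C(=O)O)cn(C4CC4)c3c2F)C1` differs from compound 3 in one place, with methyl in place of acetamido on an aromatic carbon.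

Among the measured compounds shown here, one measured step bears on this change. The same aromatic carbon carries fluoro in compound 2. Putting acetamido in place of that fluoro gave an at least 10-fold higher number from compound 2 to compound 3 (1.03 log units; beyond the scatter), a large step beyond the scatter.

With acetamido gone in compound 4, a large step back to a lower number, meaning a stronger inhibitor, is expected. The likely landing point comes from the two compounds without acetamido. Compound 1, which also carries a methyl group, gives 42 ug/mL, and compound 2 gives 46 ug/mL, two values within the scatter of each other.

In this assay the expected change is an at least 11-fold lower number from compound 3 to compound 4 (1.04 log units; beyond the scatter). For compound 4 the estimated value is 45 ug/mL, with an expected range of 18 ug/mL to 120 ug/mL.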

Compound 4, half-maximal inhibitory concentration: 9 ug/mL
Compound 4: the middle estimate sits 5.0-fold (0.70 log units) above what was measured, and the stated range ends above it.
By their numbers in this assay, from the lowest: compound 4; then compounds 1 and 2 (each within the scatter of the next). At a limit, above all of these: compound 3.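

In this assay, methyl in place of acetamido on this aromatic carbon gives an at least 55-fold lower number from compound 3 to compound 4 (1.74 log units; beyond the scatter), so the loss seen with acetamido does not carry over to methyl. Compound 3 stands at a limit of the assay, not at a number, so the full size of that step stays unknown: the limit of > 500 ug/mL in this assay, at which 1 of the 4 values shown sits.

Among the compounds shown here, what the earlier compounds did not show is that this carbon can also move the number below the level of the fluoro compound, since methyl in place of fluoro gives a 5.1-fold lower number from compound 2 to compound 4 (0.71 log units; beyond the scatter), and that methyl does not do this alone, since fluoro in place of hydrogen on an aromatic carbon, with methyl present in both compounds, gives a 4.7-fold lower number from compound 1 to compound 4 (0.67 log units; beyond the scatter).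

The compounds shown carry only fluoro, methyl and acetamido on this carbon, which leaves open where an amine, a hydroxyl group or a longer chain such as ethyl would fall between the stronger and the weaker ends of this series. They also leave open whether the gain from that added fluoro would hold with fluoro or acetamido on this carbon instead of methyl.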